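Shrinking the amide group: from cyanophenyl to methyl

The compounds below may be only part of what the source reports. "The series", "measured", "known", "first", "only" and "open" are said of these compounds alone.

Compound 1 `CN(C)CCCOc1ccc(CN2CC[C@H](NC(=O)c3cc(Cl)cc(Cl)c3)C2)cc1`: 2000 nM
Compound 2 `CN(C)CCCOc1ccc(CN2CC[C@H](NC(=O)c3ccc(C#N)cc3)C2)cc1`: < 10000 nM
Compound 3 `CN(C)CCCOc1ccc(CN2CC[C@H](NC(=O)c3ccco3)C2)cc1`: < 10000 nM

Three measured compounds share one core and differ only in the group attached to the carbonyl carbon of the amide. In an assay on HEK293 cells for binding affinity to Urotensin-2 receptor (Homo sapiens), read by radioligand binding (on this read-out lower numbers stand for stronger inhibition and higher numbers for weaker inhibition), compound 1, with 3,5-dichlorophenyl on that carbon, gives 2000 nM. Compound 2 stands at a limit of the assay and not at a number: in this assay compound 2 gives < 10000 nM. Compound 3 likewise gives only a limit. For this reason the step that the limit leaves unreadable from compound 1 to compound 2 cannot be sized, nor can a step that the limit leaves unreadable from compound 1 to compound 3 or a step that the two limits leave unreadable from compound 2 to compound 3; this follows from the limit of < 10000 nM in this assay, at which 2 of the 3 values shown sit.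

The unmeasured compound 4 `CC(=O)N[C@H]1CCN(Cc2ccc(OCCCN(C)C)cc2)C1` carries the change (methyl in place of 4-cyanophenyl on a carbonyl carbon). Going by the values given here, no measured step bears on it with a readable size, since every step among the three measured compounds is hidden by a limit. Compound 4 is therefore expected in this assay to give 6000 nM, with a range from 1500 nM to 30000 nM. Measured against the limit of compound 2, the expected step is a step that the limit leaves unreadable from compound 2 to compound 4, whose direction cannot be read from a limit, and a further limit rather than a number is held likely.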

Compound 4, inhibition constant: < 10000 nM
Compound 4 gave a limit, no number; the forecaster's own chance of this, stated with the estimate: 60%; the middle value does not contradict the limit.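

Compound 4 also gives only a limit in this assay, so none of the steps to it from compound 1, compound 2 or compound 3 can be sized, for this reason: the limit of < 10000 nM in this assay, at which 3 of the 4 values shown sit.

From the compounds shown here alone, whether methyl, furan-2-yl or 4-cyanophenyl on the carbonyl carbon gives stronger or weaker binding than 3,5-dichlorophenyl, or than one another, stays open.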